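The compounds below may be only part of what the source reports. "The series", "measured", "known", "first", "only" and "open" are said of these compounds alone.

Measured so far:
- compound 1 `Cc1ccc2[nH]c(C(=O)N[C@H]3CN(S(=O)(=O)c4ccccc4)C[C@@H]3C(=O)NC[C@H]3CCCN3)cc2c1`: 94% in a functional assay on HEK293 cells for agonist activity at growth hormone secretagogue receptor type 1 (Homo sapiens), read by HTRF and inositol phosphate accumulation, with a stated time of 90 min, in the presence of a further agent that is not named here; a lower number here means a smaller maximal response, a higher number a larger maximal response
- compound 2 `Cc1ccc2[nH]c(C(=O)N[C@H]3CN(S(=O)(=O)c4ccccc4)C[C@@H]3C(=O)N[C@@H]3CCCN(C)C3)cc2c1`: 91%
- compound 3 `Cc1ccc2[nH]c(C(=O)N[C@H]3CN(S(=O)(=O)c4ccccc4)C[C@@H]3C(=O)N[C@H]3CCCNC3)cc2c1`: 98%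

Compound 3 shows the highest of the three numbers, but both other compounds lie within the scatter of it: a number 4 percentage points higher from compound 1 to compound 3 (within the scatter) and a number 7 percentage points higher from compound 2 to compound 3 (within the scatter). All three compounds therefore reach roughly the same, near-full maximal response in this assay.

Compound 4 `O=C(N[C@H]1CN(S(=O)(=O)c2ccccc2)C[C@@H]1C(=O)N[C@H]1CCCNC1)c1cc(C2CC2)n[nH]1` differs from compound 3 in one place: 3-cyclopropyl-1H-pyrazol-5-yl in place of 5-methyl-1H-indol-2-yl on a carbonyl carbon. The measured steps, including a number 3 percentage points lower from compound 1 to compound 2 (within the scatter), all changed the group on the amide-type nitrogen and left the carbonyl side untouched, so none of them bears directly on this change. From the compounds shown here alone, the maximal response has so far been insensitive to variation elsewhere, which gives some ground to expect no step beyond the scatter, with wider uncertainty because the changed region is untested.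

Compound 4 is expected to give about 88%, with a range from 60% to 105%. This estimate means an expected step of a number 10 percentage points lower from compound 3 to compound 4 (within the scatter).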

Compound 4, largest response reached (Emax), in percent of the reference or control that the assay uses: 81%
Estimate against measurement, compound 4: 7 percentage points above, and the stated range covers the measured number.
By their numbers in this assay, from the lowest: compounds 4, 2, 1 and 3 (each within the scatter of the next, the first and the last beyond it).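

The earlier steps shown here all changed the group on the amide-type nitrogen and stayed within the scatter. Changing the group on the carbonyl carbon in this assay instead gives a number 17 percentage points lower from compound 3 to compound 4 (beyond the scatter), the only step shown that goes beyond it. The maximal response therefore depends at least modestly on this position, although nothing measured here accounts for the step.

This single swap replaces both the ring system and its substituent, so their contributions cannot be separated. A 3-methyl-1H-pyrazol-5-yl group, with methyl in place of cyclopropyl, would help to tell them apart.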